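A few compounds are considered here, and "the series" means these few. Any claim that something is new, unique, unknown or untested is made for them only; others in the source may bear on it.

Measured compounds:
compound 1 `N=C(S)CCCn1nc(-c2ccccc2)ccc1=O` gives 31.9 mg/kg in a functional assay on the whole organism (stomach) with Rattus norvegicus as the target; on this read-out higher numbers stand for an effect only at larger amounts of compound and lower numbers for an effect already at smaller amounts
compound 2 `Cc1ccc(=O)n(CCCC(=N)S)n1` gives > 100 mg/kg in this assay, a limit of the assay rather than a number
compound 3 `N=C(S)CCCCN1N=C(c2ccccc2)CCC1=O` gives 100 mg/kg in this assay

Compound 1 holds the lowest of the two numbers in this assay; compound 3 sits a step away from it, and compound 2 sits at the limit described in the limit of > 100 mg/kg in this assay, at which 1 of the 3 values shown sits. Going by the values given here, the only step measured in one place is an at least 3.1-fold higher number from compound 1 to compound 2 (0.49 log units; beyond the scatter), which concerns a change on the aromatic ring and not the chain.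

Compound 4 `N=C(S)CCCCn1nc(-c2ccccc2)ccc1=O` differs from compound 1 by a group of 4 heavy atoms (2 carbon, 1 nitrogen, 1 sulfur; no ring) in place of a group of 3 heavy atoms (1 carbon, 1 nitrogen, 1 sulfur; no ring), on a saturated chain carbon, three bonds along the chain from an aromatic nitrogen. Among the compounds with values here, no measured step bears directly on this lengthening of the chain. Within the data shown here, compound 3 also carries the longer chain but differs from compound 1 in a second place as well, so its value shows only that a compound with the longer chain reached a higher number than compound 1. On that basis the account expects for compound 4 a step of a 1.7-fold higher number from compound 1 to compound 4 (0.24 log units; within the scatter), toward a higher number, of modest size. The estimate for compound 4 is 55 mg/kg, with a range from 20 mg/kg to 150 mg/kg.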

Compound 4, dose for half-maximal effect: > 100 mg/kg
Compound 4: a limit, no number; the forecaster's own chance of this, stated with the estimate: 25%; middle value at least 1.8-fold (0.25 log units) from the limit.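

With the shared core unchanged, the change on this saturated chain carbon alone gives an at least 3.1-fold higher number from compound 1 to compound 4 (0.49 log units; beyond the scatter) in this assay, so the longer chain on its own carries a step beyond the scatter, which compound 3, differing in a second place, could not show. Compound 4 gives > 100 mg/kg, which is a limit of the assay and not a number. The step therefore has a lower bound only, and the read-out cannot show how far it extends: the limit of > 100 mg/kg in this assay, at which 2 of the 4 values shown sit.

The compounds shown leave open how a shorter chain would read in this assay, and how a carboxylic acid in place of the group that changes here would read. They also leave open whether the longer chain would count for as much with methyl in place of phenyl on the aromatic carbon.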